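A Stereocentre Inversion and Expected Permeability

The compounds below may be only part of what the source reports. "The series", "measured", "known", "first", "only" and "open" are said of these compounds alone.

Measured compounds:
- compound 1, `CC(C)[C@H](C[C@H]1OC(=O)NC1=O)c1ccc(-c2ccc3cccc(F)c3c2)[nH]c1=O`: 10.3 10^-6 cm/s
- compound 2, `CC(C)C(c1ccc(-c2ccc3cccc(F)c3c2)[nH]c1=O)C1C(=O)NC(=O)N1C`: "not determined" (no result reported)
- compound 3, `CC(C)C(/C=C1\NC(=O)NC1=O)c1ccc(-c2ccc3cccc(F)c3c2)[nH]c1=O`: 12.3 10^-6 cm/s

The study includes three measured compounds and one not yet measured. In an ADME assay on MDCK cells (Canis lupus familiaris) for permeability, in the apical to basolateral direction (on this read-out lower numbers stand for lower permeability and higher numbers for higher permeability), compound 1 gives 10.3 10^-6 cm/s. In this assay compound 3 gives 12.3 10^-6 cm/s. Of the two numbers available, that of compound 1 is the lower, but the two values lie within the scatter of each other, so no order can be read from them. In this assay compound 2 gives "not determined" (no result reported), so no number is available for it.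

The piece follows the step from compound 1 to compound 4, whose structure is `CC(C)[C@H](C[C@@H]1OC(=O)NC1=O)c1ccc(-c2ccc3cccc(F)c3c2)[nH]c1=O`. The two compounds are related as follows: the two compounds have the same atoms and bonds and differ only in configuration as drawn: 1 of 2 stereo elements differ; a stereocentre at a saturated ring carbon is drawn R in compound 1 and S in compound 4. Nothing enters and nothing leaves.

Going by the values given here, no comparison between two measured compounds involves such a change, so there is no measured step on which to lean. With the same atoms and bonds, the expectation is that the change from compound 1 to compound 4 produces no step beyond the scatter of this assay, in either direction; the estimated step is a 1.0-fold lower number from compound 1 to compound 4 (0.01 log units; within the scatter). For compound 4 the expected value in this assay is 10 10^-6 cm/s, with a range from 5 10^-6 cm/s to 20 10^-6 cm/s.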

Compound 4, apparent permeability in the MDCK assay: 10.8 10^-6 cm/s
Compound 4: middle estimate off by 1.1-fold (0.03 log units), on the low side, and the stated range covers the measured number.
By their numbers in the MDCK assay, from the lowest: compounds 1, 4 and 3 (each within the scatter of the next).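

In the MDCK assay the inversion at the saturated ring carbon comes with a 1.0-fold higher number from compound 1 to compound 4 (0.02 log units; within the scatter), so this read-out does not separate the two drawn configurations at this position. In a physicochemical assay for solubility, measured as kinetic solubility, at pH 2 (a lower number here means a less soluble compound, a higher number a more soluble compound), compound 1 gives 24400 nM and compound 4 gives 25100 nM, and these two values also lie within the scatter of each other. The earlier compounds offered no pair that differed at this stereocentre alone, whereas here the comparison rests on configuration and nothing else: the fact that compounds 1 and 4 differ only in the configuration as drawn

The compounds shown leave open whether the other stereo element, drawn the same in compound 1 and compound 4, would give an equally small step if it were inverted. They also leave open whether configuration at this carbon would still make so little difference in either read-out if the ring there gave way to a different group, such as a carboxylic acid or an amine, since this one pair speaks only for the ring it carries.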